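The compounds below may be only part of what the source reports. "The series", "measured", "known", "first", "only" and "open" are said of these compounds alone.

Measured so far in a functional assay on A2780 cells (Homo sapiens) for antiproliferative activity, read by fluorescence, with a stated time of 72 h (on this read-out lower numbers stand for stronger inhibition and higher numbers for weaker inhibition), are these compounds:
- compound 1 `CC1(C)c2[nH]nc(NC(=O)c3ccc(F)cc3)c2CN1C(=O)C1CCN(C2CC2)CC1` gives 380 nM in this assay
- compound 2 `CN1CCC(C(=O)N2Cc3c(NC(=O)Nc4cccc(F)c4)n[nH]c3C2(C)C)CC1` gives 350 nM in this assay

Compound 1 holds the higher of these two numbers, but the gap lies within the scatter, so the pair sets no order and compound 1 stands level with compound 2.

The next compound is compound 3 `CN1CCN(C(=O)N2Cc3c(NC(=O)c4ccc(F)cc4)n[nH]c3C2(C)C)CC1`, which has not yet been measured. It has 4-methylpiperazin-1-yl in place of 1-cyclopropylpiperidin-4-yl on a carbonyl carbon and otherwise matches compound 1. Among the measured compounds shown here, no measured pair isolates this change, so no direct precedent exists for its size. For the measured compounds named here, the only guide is that, set against compound 1, compound 2 differs in more than one place and still gives 350 nM, a number within the scatter.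

A small shift towards a lower number is therefore expected in this assay, but none beyond the scatter. The expected change is a 1.5-fold lower number from compound 1 to compound 3 (0.18 log units; within the scatter), an estimate with wide uncertainty. The estimate for compound 3 is 250 nM, with an expected range of 80 nM to 800 nM for the measurement.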

Compound 3, half-maximal inhibitory concentration: 180 nM
Compound 3: the middle estimate sits 1.4-fold (0.14 log units) above what was measured; measured number inside the range.
By their numbers in this assay, from the lowest: compounds 3, 2 and 1 (each within the scatter of the next, the first and the last beyond it).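

On a carbonyl carbon whose other neighbours are an amide-type nitrogen in a ring, 4-methylpiperazin-1-yl in place of 1-cyclopropylpiperidin-4-yl gives, in this assay, a 2.1-fold lower number from compound 1 to compound 3 (0.32 log units; beyond the scatter), a modest step but the first in the series that isolates a single place and lies beyond the scatter. This shows that the number in this assay responds to the group at this position, whereas the earlier pair differed in more than one place and could not be read as a step. The entering group has fewer heavy atoms, holds two ring nitrogens where the leaving group holds one, and lacks the three-membered ring, but no measurement bears on which of these differences, if any, accounts for the step.

Still open, going by these compounds, is whether the step belongs to the piperazine ring or to its methyl group, which piperazin-1-yl without the methyl, 4-acetylpiperazin-1-yl or morpholin-4-yl on the same carbonyl carbon would help to separate. Also open, on these data alone, is whether the same replacement gives a comparable step on compound 2, whose urea-linked 3-fluorophenyl group differs from the 4-fluorobenzamide of compound 1 and compound 3.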